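Chloro in place of methyl: compound 3 in the series

A few compounds are considered here, and "the series" means these few. Any claim that something is new, unique, unknown or untested is made for them only; others in the source may bear on it.

Among the measured compounds shown here, compound 2 `Cc1ccc(C(CCn2ccnc2)Oc2ccc(Cl)cc2Cl)cc1` gives 40000 nM in a functional assay on U-937 cells (Homo sapiens) for cytotoxicity (a higher number here means that more compound is tolerated, a lower number that less compound is tolerated), the lowest of the two numbers so far; its nearest neighbour, compound 1 `Clc1ccc(OC(CCn2ccnc2)c2ccccc2)c(Cl)c1`, gives 56500 nM, and the gap is within the scatter, so no order between the two is drawn. For the measured compounds named here, the only measured step, a 1.4-fold lower number from compound 1 to compound 2 (0.15 log units; within the scatter), concerns a different change. Going by the values given here, compound 3 `Clc1ccc(C(CCn2ccnc2)Oc2ccc(Cl)cc2Cl)cc1` differs from compound 2 by chloro in place of methyl on an aromatic carbon; no measured step covers this change. Among the compounds with values here, the one step seen stayed within the scatter, and compound 3 is therefore expected to show a step of a 1.1-fold lower number from compound 2 to compound 3 (0.06 log units; within the scatter), not beyond the scatter. The estimate for compound 3 is 35000 nM, between 15000 nM and 80000 nM.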

Compound 3, half-maximal cytotoxic concentration: 61000 nM
Estimate against measurement, compound 3: 1.7-fold (0.24 log units) below, and the stated range covers the measured number.
By their numbers in this assay, from the lowest: compounds 2, 1 and 3 (each within the scatter of the next).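

In this assay at this aromatic carbon, para to a large group, chloro in place of methyl gives a 1.5-fold higher number from compound 2 to compound 3 (0.18 log units; within the scatter) and chloro in place of hydrogen gives a 1.1-fold higher number from compound 1 to compound 3 (0.03 log units; within the scatter) with no step beyond the scatter. Hydrogen, methyl and chloro at this position therefore fall in no order, and chloro separates from neither of the other two. No measured evidence bears on this result.

As far as these compounds go, whether an amine, a carboxylic acid or a methoxy group at this position would give a step beyond the scatter stays open. So does the effect of any change elsewhere on the shared core.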